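Swapping a ring for a small chain on the urea

A few compounds are considered here, and "the series" means these few. Any claim that something is new, unique, unknown or untested is made for them only; others in the source may bear on it.

Two compounds share a core and were tested in a functional assay on MCF7 cells (Homo sapiens) for cytotoxicity, read by MTT assay, with a stated time of 72 h; a lower number here means a stronger inhibitor, a higher number a weaker inhibitor. Compound 1, with the structure `COc1ncc(-c2ccc3nc(NC(=O)N4CCCC4)nn3c2)cc1NS(=O)(=O)c1ccc(F)cc1`, gives 1660 nM in this assay. Compound 2, with the structure `CCN(CC)CCNC(=O)Nc1nc2ccc(-c3cnc(OC)c(NS(=O)(=O)c4ccc(C)cc4)c3)cn2n1`, gives 410 nM in this assay. Of these two numbers compound 1 has the higher one, and the gap to compound 2 lies beyond the usual scatter; the two structures differ in several places at once, so no single change can be read from them.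

Compound 3, with the structure `CNC(=O)Nc1nc2ccc(-c3cnc(OC)c(NS(=O)(=O)c4ccc(F)cc4)c3)cn2n1`, has not yet been measured. It differs from compound 1 in one place: methylamino in place of pyrrolidin-1-yl on a carbonyl carbon. Among the measured compounds shown here, no measured pair shows this change on its own. Compound 2, which carries a urea ending in a chain rather than a ring, gives 410 nM, and that is the only hint available. The step from compound 1 to compound 3 in this assay is expected to be small and toward a lower number, a 1.5-fold lower number from compound 1 to compound 3 (0.18 log units; within the scatter), within or near the scatter. Compound 3 is therefore expected to give about 1100 nM, with a plausible range from 400 nM to 3000 nM.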

Compound 3, half-maximal inhibitory concentration: 250 nM
For compound 3 the middle estimate is 4.4-fold (0.64 log units) above the measured one; measured number outside the range, below it.
By their numbers in this assay, from the lowest: compounds 3 and 2 (each within the scatter of the next); then compound 1.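

In this assay, putting methylamino in place of pyrrolidin-1-yl on a carbonyl carbon gives a 6.6-fold lower number from compound 1 to compound 3 (0.82 log units; beyond the scatter), so what sits at this position matters for the cytotoxicity read-out. Compound 1 and compound 2 could not show this, as they differ in several places at once, whereas this pair differs in one place only: the entering group has fewer heavy atoms, has no ring and carries a hydrogen-bond donor, and the lower number goes with that group. No measurement at hand explains the step.

This single step cannot separate the loss of the ring from the gain of the donor; a dimethylamino group, which has no ring and no hydrogen on its nitrogen, would pull those two apart on the same core. Also open, going by these compounds, is how the number moves as the group on this carbonyl carbon grows from methylamino to ethylamino or propylamino, and whether the step seen here would hold with a different group elsewhere on the molecule.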